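The source may report more compounds than this note shows. Statements on the series, on what has been measured and on what is new or still open speak of the compounds shown alone.

Measured compounds:
- compound 1, `COc1ccc(-c2cc(/C=C/C(=O)c3ccc(N)cc3)[nH]n2)cc1`: 1420 nM
- compound 2, `COc1cc(-c2cc(/C=C/C(=O)c3ccc(N)cc3)[nH]n2)cc(OC)c1OC`: 720 nM

Notes on the series. In a functional assay on K562 cells (Homo sapiens) for inhibition, read by sulforhodamine B assay, with a stated time of 48 h (a higher number here means a weaker inhibitor of growth, a lower number a stronger inhibitor of growth), compound 2 gives 720 nM, the lowest of the two numbers recorded. The nearest is compound 1, which in this assay gives 1420 nM; the gap between the two lies within the scatter, so no order between compound 2 and compound 1 can be read from these values.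

Compound 3, `COc1cc(-c2cc(/C=C/C(=O)c3ccc(Cl)c(Cl)c3)[nH]n2)cc(OC)c1OC`, is not yet measured in this assay. It differs from compound 2 in one place: 3,4-dichlorophenyl in place of 4-aminophenyl on a carbonyl carbon. Among the compounds with values here, no measured pair carries a change of this kind, so the size and direction of the step rest on no recorded comparison. The working expectation is a step from compound 2 to compound 3 that is small, possibly no larger than the scatter, of a 1.4-fold higher number from compound 2 to compound 3 (0.14 log units; within the scatter). On that basis compound 3 is estimated at 1000 nM in this assay, within a range of 300 nM to 3500 nM.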

Compound 3, concentration for 50% growth inhibition: 4960 nM
For compound 3 the middle estimate is 5.0-fold (0.70 log units) below the measured one; measured number outside the range, above it.
By their numbers in this assay, from the lowest: compounds 2 and 1 (each within the scatter of the next); then compound 3.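

In this assay, both earlier compounds carry 4-aminophenyl on the carbonyl carbon, so they showed nothing about this place. Replacing that group with 3,4-dichlorophenyl gives a 6.9-fold higher number from compound 2 to compound 3 (0.84 log units; beyond the scatter), so the number does respond to the group held here, and this change moves it towards weaker growth inhibition. No measurement bearing on the cause of this step is available.

Within the data shown here, the single pair changes several things at once, as the amine leaves and two chlorines enter, so it leaves open which of these goes with the step; plain phenyl, 4-chlorophenyl or 4-hydroxyphenyl on the same carbonyl carbon would separate them. Among these compounds, also open is whether a step of this size would recur with the other aryl group of compound 1 in place of the one in compound 2.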